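The source may hold more compounds than are shown below. What is called first, only, known or untested is meant among the compounds shown, and "the series" means these compounds.

Compound 1 `FC(F)(F)Oc1ccc(Oc2ccnc(N3CCC[C@@H](NC(=S)Nc4cccnc4)C3)c2Cl)c(Cl)c1` and compound 2 `FC(F)(F)Oc1ccc(Oc2ccnc(N3CCC[C@H](NC(=S)Nc4cccnc4)C3)c2Cl)c(Cl)c1` are built from the same atoms and bonds and differ only in the configuration drawn at one saturated ring carbon. In an assay on membranes from brain for binding affinity to Lysophosphatidylserine lipase ABHD12 (Mus musculus), read by fluorescence, with a stated time of 20 min (a lower number here means a stronger inhibitor, a higher number a weaker inhibitor), compound 1 gives 100000 nM. For compound 2 the result in this assay is a limit rather than a number, > 100000 nM. A third compound with a different core, compound 3 `S=C(Nc1cccnc1)NC1CCN(c2cc(OC3CCCCC3)ccn2)CC1`, gives 3400 nM in this assay. The step of a number no lower from compound 1 to compound 2 (the limit leaves the size open) cannot be sized, because one end is a limit (the limit of > 100000 nM in this assay, at which 1 of the 3 values shown sits), and the pair differs only in drawn configuration (the fact that compounds 1 and 2 differ only in the configuration as drawn). Compound 4 `FC(F)(F)Oc1ccc(Oc2ccnc(N3CCCC(NC(=S)Nc4cccnc4)C3)c2Cl)c(Cl)c1` is the same molecule again, this time with no configuration drawn: the two compounds have the same atoms and bonds; at least one stereo element is drawn with a configuration in one of them and without one in the other: 1 of 1 stereo elements differ; a stereocentre at a saturated ring carbon is drawn S in compound 2 and without a configuration in compound 4. Among the measured compounds shown here, only the step between compound 1 and compound 2 bears on this change, and its size is not readable, so no shift beyond the scatter is expected. Because compound 1 gives 100000 nM, compound 4 is expected near the top of the measured range in this assay, at 100000 nM with a range from 50000 nM to 200000 nM. The expected step is a number no higher from compound 2 to compound 4 (the limit leaves the size open).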

Compound 4, half-maximal inhibitory concentration: 90000 nM
Compound 4: middle estimate off by 1.1-fold (0.05 log units), on the high side; measured number inside the range.
By their numbers in this assay, from the lowest: compound 3; then compounds 4 and 1 (each within the scatter of the next).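

In this assay there is a 1.1-fold lower number from compound 1 to compound 4 (0.05 log units; within the scatter), so the form with no drawn configuration at this saturated ring carbon cannot be told apart from the R form. The value of compound 2, > 100000 nM, is a limit and not a number. Its step is an at least 1.1-fold lower number from compound 2 to compound 4 (0.04 log units; that floor lies within the scatter), and with the step between the two drawn forms still unreadable, no preference for R or S can be seen in these compounds.

From the compounds shown here alone, what stays open is whether a different group at this ring carbon, such as a plain amine or a carboxylic acid, would give a clearly lower number on the same core. Also open, going by these compounds, is whether the drawn configuration would matter in a related compound with a much lower number.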